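The compounds below may be only part of what the source reports. "The series", "measured", "known", "first", "only" and "open" are said of these compounds alone.

In a functional assay on SK-BR-3 cells (Homo sapiens) for cytotoxicity, read by MTT assay, with a stated time of 72 h (on this read-out higher numbers stand for an effect only at larger amounts of compound and lower numbers for an effect already at smaller amounts), compound 1 `O=c1cc(NC2CCCCC2)cc(/C=C/c2ccccc2)o1` gives 1.53 uM, and compound 3 `COc1ccc(Nc2cc(-c3ccc4ccccc4c3)oc(=O)c2)cc1` gives 0.13 uM. Compound 2 `COc1ccc(Nc2cc(C)oc(=O)c2)cc1` returns no number, only a limit: > 30 uM. Compound 4 `COc1ccc(Nc2cc(-c3ccccc3)oc(=O)c2)cc1` has not yet been measured. It differs from compound 2 at a single place, (phenyl in place of methyl on an aromatic carbon), with phenyl in place of methyl on an aromatic carbon, next to the ring oxygen. In this assay, a large move toward lower numbers, well beyond the scatter, is expected for compound 4, which would bring it closer to compound 3 at 0.13 uM. The expected size of the change is an at least 12-fold lower number from compound 2 to compound 4 (1.07 log units; beyond the scatter). The estimate for compound 4 is 2.5 uM, with an expected range from 0.5 uM to 12 uM.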

Compound 4, concentration for half-maximal effect: 0.079 uM
Beside the measured number, compound 4's estimate is 32-fold (1.50 log units) above it; the measured number lies below the stated range.
By their numbers in this assay, from the lowest: compounds 4 and 3 (each within the scatter of the next); then compound 1. At a limit, above all of these: compound 2.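

In this assay, among the compounds shown here, replacing methyl with phenyl on the aromatic carbon next to the ring oxygen gives an at least 370-fold lower number from compound 2 to compound 4 (2.57 log units; beyond the scatter), which isolates this single change as a large one, something the earlier compounds, differing in more than one place, could not do. The true size of the step cannot be fixed, since compound 2 stands only at a limit: the limit of > 30 uM in this assay, at which 1 of the 4 values shown sits.

The compounds shown leave open how this position responds to groups other than methyl and the aromatic rings, such as an amine, a carboxylic acid or a longer chain. They also leave open whether a phenyl bearing a fluorine would hold the low number.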